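Phenyl to thiophen-2-yl on the shared core

A few compounds are considered here, and "the series" means these few. Any claim that something is new, unique, unknown or untested is made for them only; others in the source may bear on it.

Compound 2 `c1ccc(-c2cn3ccnc3c(-c3ccc4ncn(C5CCCCC5)c4c3)n2)cc1` carries a phenyl group on the shared core. In a functional assay on MDA-MB-468 cells (Homo sapiens) for inhibition, read by sulforhodamine B assay, with a stated time of 48 h, tested at 10 uM (on this read-out higher numbers stand for more inhibition at the one concentration tested (going by the name of the read-out) and lower numbers for less inhibition), compound 2 gives 54.4%, the top number of the three measured compounds, though not clearly apart from all of them: compound 1 `Brc1cn2ccnc2c(-c2ccc3ncn(C4CCCCC4)c3c2)n1`, which bears bromo at that carbon, gives 44.4%, and the step of a number 10 percentage points higher from compound 1 to compound 2 (within the scatter) lies within the scatter. Compound 3 `c1cn2cc(-c3ccsc3)nc(-c3ccc4ncn(C5CCCCC5)c4c3)c2n1`, with thiophen-3-yl at that carbon, gives 21.8%. Here the steps are a number 32.6 percentage points lower from compound 2 to compound 3 (beyond the scatter) and a number 22.6 percentage points lower from compound 1 to compound 3 (beyond the scatter), both beyond the scatter.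

Compound 4 `c1csc(-c2cn3ccnc3c(-c3ccc4ncn(C5CCCCC5)c4c3)n2)c1` has not yet been measured. It differs from compound 2 in one place: thiophen-2-yl in place of phenyl on an aromatic carbon. The nearest guide is the large drop a number 32.6 percentage points lower from compound 2 to compound 3 (beyond the scatter), where a thiophene with the other attachment point took the place of phenyl, and the modest drop a number 22.6 percentage points lower from compound 1 to compound 3 (beyond the scatter) points the same way. Because of a number 32.6 percentage points lower from compound 2 to compound 3 (beyond the scatter) the expected move for compound 4 is downward and beyond the scatter, namely a number 24.4 percentage points lower from compound 2 to compound 4 (beyond the scatter). In this assay compound 4 is therefore estimated to give 30%, within a range from 10% to 52%.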

Compound 4, a percentage reported as inhibition, at one concentration (the size of the read-out at that concentration, not a potency): 15.1%
Compound 4: middle estimate off by 14.9 percentage points, on the high side, within the range that was stated.
By their numbers in this assay, from the lowest: compounds 4 and 3 (each within the scatter of the next); then compounds 1 and 2 (each within the scatter of the next).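

In this assay the step of a number 39.3 percentage points lower from compound 2 to compound 4 (beyond the scatter) is large, so the loss seen with thiophen-3-yl in place of phenyl also appears when the thiophene is attached through its other carbon, and it is not tied to one attachment point. The step of a number 6.7 percentage points lower from compound 3 to compound 4 (within the scatter) lies within the scatter, so this read-out does not separate thiophen-2-yl from thiophen-3-yl at this carbon next to the ring nitrogen. The step of a number 29.3 percentage points lower from compound 1 to compound 4 (beyond the scatter) lies beyond the scatter, which means that among these four compounds both thiophenes sit clearly apart from bromo and from phenyl, while bromo and phenyl remain within the scatter of each other, and no compound shown goes against this split.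

No measurement available here bears on why the thiophenes read so differently from phenyl at this carbon. Going by these compounds, it also remains open whether the drop belongs to thiophene alone or extends to other five-membered rings such as furan-2-yl, and how an amine or a carboxylic acid at this carbon would read.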